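This account rests on a few compounds, and the source may have more. Where it says the series, first, only, none or still open, it means among the compounds named here.

In a functional assay on SK-BR-3 cells (Homo sapiens) for antiproliferative activity (on this read-out higher numbers stand for weaker inhibition and lower numbers for stronger inhibition), compound 1 (`CC(C)=CCc1cc(C(=O)Nc2cc3ccc(OCCC4CCCCN4)c(C)c3oc2=O)ccc1O`) gives 640 nM and compound 2 (`CC(C)=CCc1cc(C(=O)Nc2cc3ccc(OCCCNCCO)c(C)c3oc2=O)ccc1O`) gives 610 nM, so the two stand level within the scatter. Compound 3 (`CC(C)=CCc1cc(C(=O)Nc2cc3ccc(OCCCN[C@H](C)c4ccccc4)c(C)c3oc2=O)ccc1O`) keeps the shared core but carries 1-phenylethyl in place of 2-hydroxyethyl on an amine nitrogen. For the measured compounds named here, the only measured step, a 1.0-fold lower number from compound 1 to compound 2 (0.02 log units; within the scatter), brought in no aromatic ring, so it is a loose guide. On that slim evidence, the expected step is a 1.4-fold lower number from compound 2 to compound 3 (0.13 log units; within the scatter), with no change beyond the scatter anticipated. For compound 3, the estimated value is 450 nM, within an expected range of 170 nM to 1200 nM.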

Compound 3, half-maximal inhibitory concentration: 1000 nM
Compound 3: middle estimate off by 2.2-fold (0.35 log units), on the low side; the range from low to high includes it.
By their numbers in this assay, from the lowest: compounds 2, 1 and 3 (each within the scatter of the next).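

Putting 1-phenylethyl, with its six-membered aromatic ring and defined stereocentre, in place of 2-hydroxyethyl on the amine nitrogen gives a 1.6-fold higher number from compound 2 to compound 3 (0.21 log units; within the scatter), so this nitrogen tolerates a larger group with no hydrogen-bond donor or acceptor of its own, with no change beyond the scatter. The comparison with the piperidin-2-yl compound reads the same: a 1.6-fold higher number from compound 1 to compound 3 (0.19 log units; within the scatter). No measurement here explains these results. Still open, going by these compounds, is whether the opposite stereocentre of 1-phenylethyl, a plain benzyl group or a carboxylic acid on this nitrogen would also stay within the scatter.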